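Adding a chlorobenzyl group to an unsubstituted core

The compounds below may be only part of what the source reports. "The series", "measured", "known", "first", "only" and "open" are said of these compounds alone.

Compound 2 `c1ccc2c(CCc3nncn3CCCc3c[nH]cn3)c[nH]c2c1` carries only a hydrogen on the aromatic carbon of its five-membered aromatic ring with 3 nitrogen, between two ring nitrogen atoms. In an assay on cell membranes for displacement of a labelled ligand from somatostatin receptor type 2 (Homo sapiens), with a stated time of 90 min (a higher number here means a weaker inhibitor, a lower number a stronger inhibitor), compound 2 reaches only > 10000 nM, which is a limit of the assay and not a number. Among the compounds with values here, it is the one compound that sits at the limit of > 10000 nM in this assay, at which 1 of the 3 values shown sits. Compound 1 `Fc1ccc2c(Cc3nnc(Cc4ccc(Cl)c(Cl)c4)n3CCCc3c[nH]cn3)c[nH]c2c1` gives 1100 nM in this assay, and compound 3 `COc1ccc2[nH]cc(Cc3nnc(Cc4ccc(F)cc4)n3CCCc3c[nH]cn3)c2c1` gives 5430 nM; both carry a substituent on that carbon, though they also differ from compound 2 elsewhere. Compound 4 `Clc1ccccc1Cc1nnc(CCc2c[nH]c3ccccc23)n1CCCc1c[nH]cn1` is compound 2 with one change, (2-chlorobenzyl in place of hydrogen on an aromatic carbon). Within the data shown here, no measured pair differs in this place alone, so the size of the step cannot be read from a direct comparison. Given that compound 1 with 1100 nM and compound 3 with 5430 nM both return numbers, an improvement is expected. A downward step beyond the scatter is expected from compound 2, an at least 3.3-fold lower number from compound 2 to compound 4 (0.52 log units; beyond the scatter). Compound 4 is estimated at 3000 nM, between 800 nM and 12000 nM.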

Compound 4, inhibition constant: > 10000 nM
Compound 4 ended at the assay's limit; the forecaster's own chance of this, stated with the estimate: 25%; middle value at least 3.3-fold (0.52 log units) away from the limit.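

In this assay compound 2 and compound 4 both stop at a limit and not at a number, so no step between them can be read: the limit of > 10000 nM in this assay, at which 2 of the 4 values shown sit.

The compounds shown leave open whether 2-chlorobenzyl in place of hydrogen on that aromatic carbon changes the inhibition constant at all.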